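The source may hold more compounds than are shown below. What is called first, only, known or untested is meant among the compounds shown, and "the series" means these compounds.

In a functional assay on HUVEC cells (Homo sapiens) for cytotoxicity (on this read-out higher numbers stand for an effect only at larger amounts of compound and lower numbers for an effect already at smaller amounts), three compounds with a shared core have been measured. Compound 1 `COC1=C(C)C(=O)/C(=C(O)/C=C/c2cccc(OC)c2)C(=O)C1(C)C` gives 1.6 ug/mL, compound 2 `COC1=C(C)C(=O)/C(=C(O)/C=C/c2ccccc2OC)C(=O)C1(C)C` gives 1.7 ug/mL and compound 3 `COC1=C(C)C(=O)/C(=C(O)/C=C/c2c(C)cccc2C)C(=O)C1(C)C` gives 3 ug/mL, so compound 3 lies within the scatter of both others. Compound 4 `COC1=C(C)C(=O)/C(=C(O)/C=C/c2cccs2)C(=O)C1(C)C` keeps the core but carries thiophen-2-yl in place of 2,6-dimethylphenyl on a double-bonded chain carbon bound to a double-bonded chain carbon. The steps at this place are a 1.9-fold higher number from compound 1 to compound 3 (0.27 log units; within the scatter), a 1.8-fold higher number from compound 2 to compound 3 (0.25 log units; within the scatter) and a 1.1-fold higher number from compound 1 to compound 2 (0.03 log units; within the scatter), all within the scatter. None introduces thiophen-2-yl, so the evidence is indirect. The expected step, a 1.4-fold lower number from compound 3 to compound 4 (0.13 log units; within the scatter), therefore stays within the scatter. Compound 4 is estimated at 2.2 ug/mL, with an expected range from 1 ug/mL to 5 ug/mL.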

Compound 4, concentration for half-maximal effect: 2.5 ug/mL
Compound 4: the middle estimate sits 1.1-fold (0.06 log units) below what was measured; the measured number falls inside the stated range.
By their numbers in this assay, from the lowest: compounds 1, 2, 4 and 3 (each within the scatter of the next).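

In this assay, within the data shown here, the place on a double-bonded chain carbon bound to a double-bonded chain carbon also carries a five-membered aromatic ring with 1 hetero atom, and the result is a 1.2-fold lower number from compound 3 to compound 4 (0.08 log units; within the scatter) and a 1.5-fold higher number from compound 2 to compound 4 (0.17 log units; within the scatter) and a 1.6-fold higher number from compound 1 to compound 4 (0.19 log units; within the scatter) with no step leaving the scatter. Thiophen-2-yl, with 5 heavy atoms against 8 in 2,6-dimethylphenyl, thus stands apart from none of the six-membered aromatic rings shown. No supporting data bear on this flat result. From the compounds shown here alone, whether an amine, a carboxylic acid or a longer chain at this place would give a step beyond the scatter stays open.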